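Chloro for methoxy on the aryl ring of compound 2

This account rests on a few compounds, and the source may have more. Where it says the series, first, only, none or still open, it means among the compounds named here.

Measured so far:
compound 1 `Nc1nc(-c2ccc(Cl)cc2)cn1/N=C/c1cc2ccccc2nc1Cl`: 28000 nM
compound 2 `COc1ccc(-c2cn(/N=C/c3cc4cc(C)ccc4nc3Cl)c(N)n2)cc1`: 12200 nM

In an ADME assay on HUVEC cells (Homo sapiens) for cytotoxicity, read by MTT assay, with a stated time of 48 h (a lower number here means a stronger inhibitor, a higher number a weaker inhibitor), compound 2 gives 12200 nM, the lowest of the two numbers; the nearest, compound 1, gives 28000 nM, a gap beyond the scatter. Compound 3 `Cc1ccc2nc(Cl)c(/C=N/n3cc(-c4ccc(Cl)cc4)nc3N)cc2c1` differs from compound 2 by chloro in place of methoxy on an aromatic carbon. Among the measured compounds shown here, no pair of measured compounds isolates this change, so its effect is not known here. A small step toward a higher number, at about the edge of the scatter, is expected from compound 2 to compound 3 in this assay, a 1.5-fold higher number from compound 2 to compound 3 (0.17 log units; within the scatter). Compound 3 is estimated at 18000 nM, in the range 8000 nM to 40000 nM.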

Compound 3, half-maximal inhibitory concentration: 38500 nM
For compound 3 the middle estimate is 2.1-fold (0.33 log units) below the measured one, and the stated range covers the measured number.
By their numbers in this assay, from the lowest: compound 2; then compounds 1 and 3 (each within the scatter of the next).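

In this assay, the swap of 4-methoxyphenyl to 4-chlorophenyl gives a 3.2-fold higher number from compound 2 to compound 3 (0.50 log units; beyond the scatter) and so shows that this position, para to a large group, responds to chloro in place of methoxy. Methyl in place of hydrogen on the core gives a 1.4-fold higher number from compound 1 to compound 3 (0.14 log units; within the scatter) and cannot be told apart from repeat measurements. Nothing measured here bears on why the methoxy to chloro change shifts the number.

Going by these compounds, how an amine or a carboxylic acid would behave at this position stays open. So does whether the methoxy to chloro step holds on the core of compound 1, without the methyl.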